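This account rests on a few compounds, and the source may have more. Where it says the series, first, only, none or still open, it means among the compounds named here.

Compound 1 `CC/N=C(\N)Nc1ccc(Sc2ccc(OC)cc2)cc1` gives 251 nM in an assay (Rattus norvegicus) for binding affinity to prostacyclin receptor (Homo sapiens), read by radioligand binding; a higher number here means a weaker inhibitor, a lower number a stronger inhibitor.
Compound 2 `CC/N=C(\N)Nc1ccc(Sc2ccc(Cl)cc2)cc1` gives 631 nM in this assay.

Among the two numbers measured so far, compound 2 holds the higher one; the single recorded step between the two, a 2.5-fold higher number from compound 1 to compound 2 (0.40 log units; beyond the scatter), separates it from compound 1, the only other compound in hand. Compound 3 `CC/N=C(\N)NCc1ccc(Sc2ccc(Cl)cc2)cc1` has not yet been measured in this assay. It differs from compound 2 in the group attached to the core: a group of 7 heavy atoms (4 carbon, 3 nitrogen; no ring) in place of a group of 6 heavy atoms (3 carbon, 3 nitrogen; no ring), on an aromatic carbon. Among the measured compounds shown here, no measured step bears directly on a change of this kind. For the measured compounds named here, the one step in hand, a 2.5-fold higher number from compound 1 to compound 2 (0.40 log units; beyond the scatter), concerns the exchange of methoxy for chloro on the other ring and gives no guidance on how this assay responds to the larger group taking the place of the smaller one. The expectation for compound 3 therefore rests on the structural change alone and carries a wide range. Compound 3 is estimated at 1200 nM, with a range from 250 nM to 6000 nM. This estimate corresponds to an expected step of a 1.9-fold higher number from compound 2 to compound 3 (0.28 log units; within the scatter), a weakening that may or may not reach beyond the scatter.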

Compound 3, inhibition constant: < 10000 nM
Compound 3: a limit, no number; the forecaster's own chance of this, stated with the estimate: 10%; the middle value is on the limit's open side.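

In this assay compound 3 gives < 10000 nM, which is a limit of the assay and not a number. The step from compound 2 to compound 3 therefore cannot be read. The compounds shown leave open how the group of 7 heavy atoms in compound 3 compares with the group of 6 heavy atoms in compound 2 in this assay.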